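Thiophen-2-yl in place of 4-fluorophenyl: working notes

The source may hold more compounds than are shown below. What is called first, only, known or untested is meant among the compounds shown, and "the series" means these compounds.

The series shares one core, seen in compound 1 (`Nc1ccccc1NC(=O)c1ccc(CNCc2nc(-c3ccc(C(F)(F)F)cc3)no2)cc1`), compound 2 (`Nc1ccccc1NC(=O)c1ccc(CNCc2nc(-c3ccc(Cl)cc3)no2)cc1`) and compound 3 (`Nc1ccccc1NC(=O)c1ccc(CNCc2nc(-c3ccc(F)cc3)no2)cc1`). In a functional assay on A549 cells (Homo sapiens) for inhibition, read by MTT assay, with a stated time of 72 h (on this read-out higher numbers stand for weaker inhibition and lower numbers for stronger inhibition), compound 1 gives 100000 nM, compound 2 gives 13500 nM and compound 3 gives 10700 nM. Compound 3 therefore sits level with compound 2 at the low end of the three numbers, since a 1.3-fold lower number from compound 2 to compound 3 (0.10 log units; within the scatter) lies within the scatter. Compound 1 stands apart, with modest steps beyond the scatter: a 7.4-fold lower number from compound 1 to compound 2 (0.87 log units; beyond the scatter) and a 9.3-fold lower number from compound 1 to compound 3 (0.97 log units; beyond the scatter).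

Compound 4 (`Nc1ccccc1NC(=O)c1ccc(CNCc2nc(-c3cccs3)no2)cc1`) carries thiophen-2-yl in place of 4-fluorophenyl on an aromatic carbon. For the measured compounds named here, no measured step covers this exchange, as all three only swap trifluoromethyl, chloro and fluoro. With only compound 1 standing off, through a 9.3-fold lower number from compound 1 to compound 3 (0.97 log units; beyond the scatter), no step beyond the scatter is expected in this assay. The estimated step is a 1.1-fold higher number from compound 3 to compound 4 (0.05 log units; within the scatter). For compound 4 the estimated value is 12000 nM, with an expected range of 5000 nM to 35000 nM.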

Compound 4, half-maximal inhibitory concentration: > 100000 nM
Compound 4: a limit, no number (the forecaster's own chance of this, stated with the estimate: 10%); middle value at least 8.3-fold (0.92 log units) from the limit.
By their numbers in this assay, from the lowest: compounds 3 and 2 (each within the scatter of the next); then compound 1.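

For compound 4 the reading in this assay is a limit of the assay and not a number: the limit of > 100000 nM in this assay, at which 1 of the 4 values shown sits.

Even so, the exchange at this carbon, between two ring nitrogen atoms, is the first shown to separate a compound from the low end of the series by replacing the aromatic ring itself, with an at least 9.3-fold higher number from compound 3 to compound 4 (0.97 log units; beyond the scatter) and an at least 7.4-fold higher number from compound 2 to compound 4 (0.86 log units; beyond the scatter), whereas the earlier steps changed only the substituent on the phenyl ring. The remaining step, a number no lower from compound 1 to compound 4 (the limit leaves the size open), cannot be read, so thiophen-2-yl and 4-(trifluoromethyl)phenyl cannot be ordered at this position.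

The compounds shown leave open whether the loss follows the sulfur-containing ring or the lower heavy-atom count. Unsubstituted phenyl, thiophen-3-yl and pyridin-3-yl at the same carbon would bear on that question.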